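The source may report more compounds than this note shows. Statements on the series, on what has been measured and on what is new or still open speak of the compounds shown alone.

Measured in a toxicity assay on the whole organism (strain Icem-CET (SPF Caw)) for cytotoxicity, with Mus musculus as the target; on this read-out higher numbers stand for an effect only at larger amounts of compound and lower numbers for an effect already at smaller amounts:
compound 1 `COc1ccc(/C(C)=C(\C)C(=O)NC2CC2)cc1`: 250 mg/kg
compound 2 `C#CCNC(=O)/C(C)=C(\C)c1ccc(OC)cc1`: 150 mg/kg
compound 3 `C=CCNC(=O)/C(C)=C(\C)c1ccc(C)cc1`: 100 mg/kg

Compound 2 stands second highest of the three numbers. Its nearest neighbour is compound 3, whose value in this assay is within the scatter of it, and the furthest is compound 1, also within the scatter; the three measured compounds therefore do not separate from one another on this read-out.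

The next compound is compound 4 `C#CCNC(=O)/C(C)=C(\C)c1ccccc1`. It differs from compound 2 in one place: hydrogen in place of methoxy on an aromatic carbon. The ring substituent is removed while the rest of the shared core, including the propargyl on the amide-type nitrogen, is kept.

Within the data shown here, only one single-point step has been measured, a 1.7-fold lower number from compound 1 to compound 2 (0.22 log units; within the scatter), and it concerns the amide-type nitrogen, not the aromatic ring; it gives no direct guidance for the present change. Compound 3, which carries a methyl on the ring, differs from compound 2 in two places and is not a clean comparison, but its value lies within the scatter of compound 2. Among the measured compounds shown here, no measured step reaches beyond the scatter, and the methoxy-to-hydrogen change has no precedent, so no step beyond the scatter is expected in this assay, in either direction.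

For compound 4 the expected value is 150 mg/kg, with a range from 75 mg/kg to 300 mg/kg, which means an estimated step of no change at the digits printed from compound 2 to compound 4 (within the scatter).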

Compound 4, dose for half-maximal effect: 150 mg/kg
Compound 4: middle estimate and measured number agree at the digits printed; measured number inside the range.
By their numbers in this assay, from the lowest: compounds 3, 2, 4 and 1 (each within the scatter of the next, the first and the last beyond it).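

In this assay, among these compounds, hydrogen in place of methoxy on the aromatic carbon para to a large group gives no change at the digits printed from compound 2 to compound 4 (within the scatter) and thereby provides the first reading of a single change on the ring, as the earlier step concerned only the amide-type nitrogen. With the propargyl on the amide-type nitrogen and the rest of the shared core kept, this pair shows that the read-out does not separate the methoxy compound from its unsubstituted counterpart, so loss of the methoxy alone produces no step beyond the scatter here. The data offer no measured basis for interpreting this lack of separation at the ring position.

As far as these compounds go, whether an amine, a carboxylic acid or a longer alkoxy chain at this ring position would give a step beyond the scatter in this assay remains open. Also open, from the compounds shown here alone, is whether hydrogen in place of methoxy would behave in the same way with the cyclopropyl of compound 1 on the amide-type nitrogen.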